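Nitrophenyl to trifluorophenyl: compound 2 to compound 4

The compounds below may be only part of what the source reports. "The series", "measured", "known", "first", "only" and "open" are said of these compounds alone.

Of the compounds shown here, three on a shared core have been tested in a functional assay on ECV-304 cells (Homo sapiens) for cytotoxicity; a lower number here means a stronger inhibitor, a higher number a weaker inhibitor. Compound 1 `O=C1/C(=C/c2ccc(Cl)c(Cl)c2)SC(=S)N1NS(=O)(=O)c1cccs1` reaches only a limit of the assay, > 50000 nM. Compound 2 `O=C1/C(=C/c2ccc([N+](=O)[O-])cc2)SC(=S)N1NS(=O)(=O)c1ccccc1` likewise shows only a limit, > 50000 nM. Compound 3 `O=C1/C(=C/c2ccc(F)c(F)c2F)SC(=S)N1NS(=O)(=O)c1ccccc1` also gives only a limit, > 50000 nM. Compound 2 therefore stands at the same limit as the other two, and no order among them can be read. The measured step that the two limits leave unreadable from compound 2 to compound 3 bears most closely on the change at hand, yet its size cannot be read. Compound 4 `O=C1/C(=C/c2cc(F)c(F)cc2F)SC(=S)N1NS(=O)(=O)c1ccccc1` differs from compound 2 by 2,4,5-trifluorophenyl in place of 4-nitrophenyl on a double-bonded chain carbon bound to a double-bonded ring carbon. Because the limit of > 50000 nM in this assay, at which 3 of the 3 values shown sit, there is no number to anchor a shift in either direction. Compound 4 is therefore expected to sit near 60000 nM, within 20000 nM to 200000 nM. The expected step that the limit leaves unreadable from compound 2 to compound 4 is thus estimated as none beyond the scatter.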

Compound 4, half-maximal inhibitory concentration: > 50000 nM
Compound 4: a limit, no number; the forecaster's own chance of this, stated with the estimate: 85%; the middle value lies beyond the limit too.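

No new step can be read: compound 2, compound 3 and compound 4 all stand at a limit of the assay, not at a number. The compounds shown leave open how strongly any of them inhibits in this assay, and whether these ring changes shift it at all.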